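This account rests on a few compounds, and the source may have more. Where it says the series, first, only, none or still open, it means among the compounds named here.

In a functional assay on CNE-2 cells (Homo sapiens) for antiproliferative activity, read by sulforhodamine B assay, with a stated time of 48 h (on this read-out higher numbers stand for weaker inhibition and lower numbers for stronger inhibition), compound 1 `COc1cccc(/C=C/C(=O)C(=Cc2ccc(O)c(F)c2)C(=O)/C=C/c2cccc(OC)c2OC)c1OC` gives 260 nM, while compound 2 `COc1ccc(/C=C/C(=O)C(=Cc2ccc(O)c(F)c2)C(=O)/C=C/c2ccc(OC)cc2OC)c(OC)c1` gives 2830 nM, the higher of the two numbers and beyond the scatter. Compound 3 `COc1ccc(/C=C/C(=O)C(=Cc2ccc(OC)c(O)c2)C(=O)/C=C/c2ccc(OC)cc2OC)c(OC)c1` differs from compound 2 at one place: 3-hydroxy-4-methoxyphenyl in place of 3-fluoro-4-hydroxyphenyl on a double-bonded chain carbon bound to a double-bonded chain carbon, with 3-hydroxy-4-methoxyphenyl in place of 3-fluoro-4-hydroxyphenyl on a double-bonded chain carbon bound to a double-bonded chain carbon. Among the compounds with values here, no measured pair shows this change, so no step beyond the scatter is expected in this assay, with a slight lean toward lower numbers. The estimated step is a 1.3-fold lower number from compound 2 to compound 3 (0.11 log units; within the scatter). For compound 3 the expected value is 2200 nM, within an estimated range of 700 nM to 6500 nM.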

Compound 3, half-maximal inhibitory concentration: 760 nM
The estimate for compound 3 lay 2.9-fold (0.46 log units) above the measured number; the measured number falls inside the stated range.
By their numbers in this assay, from the lowest: compound 1; then compound 3; then compound 2.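

The aryl group on this double-bonded chain carbon is not a silent position in this assay: with the rest of the structure held, the exchange gives a 3.7-fold lower number from compound 2 to compound 3 (0.57 log units; beyond the scatter), a step beyond the scatter. The 3-hydroxy-4-methoxyphenyl group is thus preferred over 3-fluoro-4-hydroxyphenyl here, in the setting of compound 2. Nothing at hand gives a reason for this step.

Going by these compounds, whether the entering methoxy, the loss of fluorine or the moved hydroxy carries the step remains open. On these data alone, how an amine in place of that hydroxy would read here also remains open.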